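Aminopyrimidine series: aryl swap

The source may report more compounds than this note shows. Statements on the series, on what has been measured and on what is new or still open speak of the compounds shown alone.

Measured so far:
compound 1 `O=C(NCCCNc1nc(Nc2cccc(F)c2)ncc1Br)C1CCC1` 2 nM
compound 2 `O=C(NCCCNc1nc(NCc2ccc(F)cc2)ncc1C1CC1)c1cccs1` > 10000 nM
compound 3 `O=C(NCCCNc1nc(Nc2cnn(C3CC3)c2)ncc1C1CC1)C1CCC1` 10 nM

In an assay on isolated protein for inhibition of serine/threonine-protein kinase TBK1 (Homo sapiens) (a higher number here means a weaker inhibitor, a lower number a stronger inhibitor), compound 1 gives 2 nM. Compound 2 gives only a limit, > 10000 nM, in this assay. Compound 3 gives 10 nM and so holds the higher of the two numbers, with compound 1 the nearest measured neighbour; that gap is beyond the usual scatter.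

Compound 4 `O=C(NCCCNc1nc(Nc2cccnc2)ncc1C1CC1)C1CCC1` is not yet measured. It differs from compound 3 in one place: pyridin-3-yl in place of 1-cyclopropyl-1H-pyrazol-4-yl on a nitrogen on an aromatic ring. Within the data shown here, no measured pair shows this kind of change, so no size can be read off directly. The step from compound 3 to compound 4 is expected to be small, perhaps a modest weakening, a 2.0-fold higher number from compound 3 to compound 4 (0.30 log units; within the scatter). For compound 4 in this assay the estimate is 20 nM, from 5 nM to 80 nM.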

Compound 4, half-maximal inhibitory concentration: 13 nM
For compound 4 the middle estimate is 1.5-fold (0.19 log units) above the measured one; measured number inside the range.
By their numbers in this assay, from the lowest: compound 1; then compounds 3 and 4 (each within the scatter of the next). At a limit, above all of these: compound 2.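

With pyridin-3-yl in place of 1-cyclopropyl-1H-pyrazol-4-yl on a nitrogen on an aromatic ring, this assay shows a 1.3-fold higher number from compound 3 to compound 4 (0.11 log units; within the scatter). This position therefore accepts a six-membered aromatic ring in place of a five-membered one, and in this pair the three-membered carbon ring can go without a change beyond the scatter. Nothing shown gives a reason for this step. Still open, on these data alone, is whether a morpholine or a carboxylic acid carried on the pyridin-3-yl ring would keep this level. Compounds 1 and 2 differ from compound 4 in more than one place, so they cannot settle this.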